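Benzyl for Phenyl on the Core of Compound 1

The compounds below may be only part of what the source reports. "The series", "measured", "known", "first", "only" and "open" are said of these compounds alone.

Compound 1 `Nc1ccccc1NC(=O)c1ccc(CNC2=NC(=O)C(c3ccccc3)N2)cc1` was tested in an assay on isolated protein for inhibition of protein deacetylase HDAC6 (Homo sapiens), read by fluorescence, with stated times of 3 h and 60 min; on this read-out higher numbers stand for weaker inhibition and lower numbers for stronger inhibition. In this assay compound 1 gives only a limit, > 20000 nM, not a number. Compound 2 `CC(C)(C)OC(=O)N1C(NCc2ccc(C(=O)Nc3ccccc3N)cc2)=NC(=O)C1Cc1c[nH]c2ccccc12` likewise gives only a limit, > 20000 nM. Compound 3 `O=C(NO)c1ccc(CNc2nccc(-c3cccnc3)n2)cc1` gives 42 nM in this assay, a different kind of molecule from the others. So compound 1 stands at the weak end of what has been seen, at the limit of > 20000 nM in this assay, at which 2 of the 3 values shown sit. Compound 4 `Nc1ccccc1NC(=O)c1ccc(CNC2=NC(=O)C(Cc3ccccc3)N2)cc1` differs from compound 1 by benzyl in place of phenyl on a saturated ring carbon. Within the data shown here, no measured pair shows a change of this kind, so the step from compound 1 to compound 4 is expected to stay within the scatter, with compound 4 again likely at the limit. Compound 4 is estimated at 30000 nM, between 8000 nM and 100000 nM, an expected step that the limit leaves unreadable from compound 1 to compound 4.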

Compound 4, half-maximal inhibitory concentration: > 20000 nM
Compound 4 gave a limit, no number; the forecaster's own chance of this, stated with the estimate: 75%; the middle value is on the limit's open side.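

Compound 1 and compound 4 both give a limit rather than a number, so no step can be read between them: the limit of > 20000 nM in this assay, at which 3 of the 4 values shown sit.

As far as these compounds go, whether benzyl and phenyl on the saturated ring carbon differ at all in inhibition stays open.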